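Swapping a pyrazinyl group for a fluorophenyl group

A few compounds are considered here, and "the series" means these few. Any claim that something is new, unique, unknown or untested is made for them only; others in the source may bear on it.

Measured compounds:
Compound 1 `COc1ccc(CNC(=O)c2cc(-c3cncc(C)c3)ncc2-c2cnccn2)nc1OC`: 31000 nM
Compound 2 `COc1ccc(CNC(=O)c2nc(-c3cncc(C)c3)ncc2-c2ccccc2)nc1OC`: 23000 nM

In an assay on CHO cells for displacement of a labelled ligand from Orexin/Hypocretin receptor type 1 variant I408V (Homo sapiens), read by scintillation counting (a higher number here means a weaker inhibitor, a lower number a stronger inhibitor), compound 1 gives 31000 nM, the highest of the two numbers, while compound 2 gives 23000 nM, within the scatter of compound 1. Compound 3 `COc1ccc(CNC(=O)c2cc(-c3cncc(C)c3)ncc2-c2ccccc2F)nc1OC` differs from compound 1 in that (2-fluorophenyl in place of pyrazin-2-yl on an aromatic carbon). Compound 2, whose phenyl-bearing core also reads weakly, offers the only hint; its value is close to compound 1. Among the compounds with values here, no step within the scatter is expected, so compound 3 is estimated near compound 1, with a 1.4-fold lower number from compound 1 to compound 3 (0.15 log units; within the scatter). Compound 3 is expected at 22000 nM, between 7000 nM and 70000 nM.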

Compound 3, inhibition constant: 8600 nM
Estimate against measurement, compound 3: 2.6-fold (0.41 log units) above, and the stated range covers the measured number.
By their numbers in this assay, from the lowest: compound 3; then compounds 2 and 1 (each within the scatter of the next).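

In this assay, 2-fluorophenyl in place of pyrazin-2-yl gives a 3.6-fold lower number from compound 1 to compound 3 (0.56 log units; beyond the scatter) and shows that the number at this position depends on the group it carries. The swap removes the ring nitrogens and adds fluorine in one move, so the data cannot separate these two changes. Nothing measured here explains the step. As far as these compounds go, whether the fluorine matters on this core stays open, and so does whether a 2-chlorophenyl or 2-methoxyphenyl group would give a similar number.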